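The source may hold more compounds than are shown below. What is called first, only, known or untested is meant among the compounds shown, and "the series" means these compounds.

Measured in a functional assay on KB cells (Homo sapiens) for antiproliferative activity, read by colorimetric assay and MTT assay; on this read-out lower numbers stand for stronger inhibition and higher numbers for weaker inhibition:
- Compound 1 `COc1ccc(S(=O)(=O)Nc2cccc3cc[nH]c23)cc1`: 0.67 ug/mL
- Compound 2 `COc1ccc(S(=O)(=O)Nc2cccc3cc(O)[nH]c23)cc1`: 0.1 ug/mL
- Compound 3 `O=S(=O)(Nc1ccc(Cl)c2cc[nH]c12)c1ccc(Cl)cc1`: 9.7 ug/mL

Of these three, compound 2 gives the lowest number, 0.1 ug/mL. Compound 4 `O=S(=O)(Nc1cccc2cc(O)[nH]c12)c1ccc(Cl)cc1` has not been measured. It differs from compound 2 as follows: chloro in place of methoxy on an aromatic carbon. Among the compounds with values here, no measured step covers this change. Within the data shown here, the one measured step, a 6.7-fold lower number from compound 1 to compound 2 (0.83 log units; beyond the scatter), is hydroxy in place of hydrogen, which compound 2 and compound 4 share, so it only sets the starting level. Compound 3 also carries chloro rather than methoxy and shows a higher number than compound 1, but it differs in a further place, so it offers only a weak hint. A modest rise is therefore expected, an estimated 3.0-fold higher number from compound 2 to compound 4 (0.48 log units; beyond the scatter). For compound 4 the estimate is 0.3 ug/mL, with an expected range of 0.06 ug/mL to 1.5 ug/mL.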

Compound 4, half-maximal inhibitory concentration: 1.1 ug/mL
Compound 4: middle estimate off by 3.7-fold (0.56 log units), on the low side, and the stated range covers the measured number.
By their numbers in this assay, from the lowest: compound 2; then compounds 1 and 4 (each within the scatter of the next); then compound 3.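

In this assay, within the data shown here, chloro in place of methoxy on the six-membered aromatic ring of carbon only, para to a large group, gives an 11-fold higher number from compound 2 to compound 4 (1.04 log units; beyond the scatter) and is the only single-place reading of this change. With the hydroxy group common to both compounds, the number at this position clearly depends on the group present, and methoxy gives the lower number of the two. No available evidence accounts for the size of this step.

Going by these compounds, it remains open how fluoro, ethoxy or an amine would read at this position. On these data alone, it is also open whether the same step would appear on the core without the hydroxy group.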